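This account rests on a few compounds, and the source may have more. Where it says the series, first, only, none or still open, it means among the compounds named here.

In a functional assay on HepG2 cells (Homo sapiens) for antiproliferative activity, read by MTT assay, with a stated time of 24 h (on this read-out higher numbers stand for weaker inhibition and lower numbers for stronger inhibition), two compounds have been measured so far. Compound 1 `C=CCc1cc(-c2cccc(C(F)(F)F)c2)ccc1O` gives 58300 nM and compound 2 `C=CCc1cc(-c2ccc(OC)cc2)cc(CC=C)c1O` gives 69200 nM. These values lie within the usual scatter of each other, so compound 1 cannot be ranked against compound 2. Compound 3 `C=CCc1cc(-c2ccccc2)ccc1O` has yet to be measured in this assay. It differs from compound 1 in one place: hydrogen in place of trifluoromethyl on an aromatic carbon. Among the compounds with values here, no measured pair shows this change on its own, so its size is not known from the data. The expectation therefore rests only on compound 1 at 58300 nM, and little movement beyond the scatter is foreseen, with any drift towards weaker inhibition. The expected change is a 1.1-fold higher number from compound 1 to compound 3 (0.05 log units; within the scatter). For compound 3 the estimated value is 65000 nM, with an expected range of 32000 nM to 130000 nM.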

Compound 3, half-maximal inhibitory concentration: > 100000 nM
Compound 3: no number, only a limit; the forecaster's own chance of this, stated with the estimate: 15%; at least 1.5-fold (0.18 log units) between middle value and limit.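

Within the data shown here, compound 3 and compound 1 form the first pair that isolates hydrogen in place of trifluoromethyl on this aromatic carbon, meta to a large group, and in this assay that pair shows an at least 1.7-fold higher number from compound 1 to compound 3 (0.23 log units; that floor lies within the scatter). Hydrogen at this position therefore gave no sign of stronger inhibition, although the floor alone cannot establish that trifluoromethyl contributes anything here. The value for compound 3 is a limit and not a number, so the step is only a floor and its true size stays unread: the limit of > 100000 nM in this assay, at which 1 of the 3 values shown sits.

The compounds shown leave open how far the step extends beyond that floor. They also do not tell whether a different group on this carbon, such as a chlorine atom or an amine, would give a value like that of compound 1.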